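The compounds below may be only part of what the source reports. "The series", "measured", "known", "first", "only" and "open" are said of these compounds alone.

Measured compounds in a functional assay on COS-7 cells (Chlorocebus aethiops) for inhibition, read by MTT assay; a higher number here means a weaker inhibitor, a lower number a stronger inhibitor:
compound 1, `Cc1ccc2c(c1)/C(=N/NC(=S)N/N=C/c1c(Cl)cccc1Cl)C(=O)N2`: 3870 nM
compound 2, `Cc1ccc2c(c1)/C(=N/NC(=S)N/N=C/c1ccccn1)C(=O)N2`: 2120 nM
compound 3, `Cc1ccc2c(c1)/C(=N/NC(=S)N/N=C/c1ccc(-c3ccccc3)cc1)C(=O)N2`: > 50000 nM

The three share one core and differ only in the group on the carbon with a double bond to nitrogen. Among the compounds with values here, compound 3 stands at the limit of this assay and has no number; it is the one value that sits at the limit of > 50000 nM in this assay, at which 1 of the 3 values shown sits. Within the data shown here, the single measured step, a 1.8-fold lower number from compound 1 to compound 2 (0.26 log units; within the scatter), exchanges one ring for another on that carbon and does not touch the change now in question.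

Compound 4, `Cc1ccc2c(c1)/C(=N/NC(=S)N/N=C/c1ccc(Br)cc1)C(=O)N2`, differs from compound 3 by bromo in place of phenyl on an aromatic carbon. Among the measured compounds shown here, no measured step bears directly on this exchange, so the expectation can only rest on the other two members. Compound 4 is expected to return a number in this assay because compound 1 gives 3870 nM and compound 2 gives 2120 nM with other groups on that carbon. The estimated step is an at least 7.1-fold lower number from compound 3 to compound 4 (0.85 log units; beyond the scatter). Compound 4 is therefore estimated at 7000 nM, somewhere between 1500 nM and 50000 nM.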

Compound 4, half-maximal inhibitory concentration: > 50000 nM
Compound 4: only a limit was reported; the forecaster's own chance of this, stated with the estimate: 25%; at least 7.1-fold (0.85 log units) between middle value and limit.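

In this assay compound 4 joins compound 3 at a limit of the assay rather than at a number: the limit of > 50000 nM in this assay, at which 2 of the 4 values shown sit. Both values are limits, so the step between these two compounds cannot be read, and nothing can be said about how phenyl and bromo compare at this place. The readable steps are large, an at least 23-fold higher number from compound 2 to compound 4 (1.37 log units; beyond the scatter) and an at least 12-fold higher number from compound 1 to compound 4 (1.11 log units; beyond the scatter), and among the four compounds the two with phenyl or bromo on that aromatic carbon, para to a large group, are the two at the limit.

The compounds shown leave open whether a hydrogen, a fluoro or an amine on that aromatic carbon would return a number in this assay. They also leave open how far past the limit compound 3 and compound 4 lie.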